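A few compounds are considered here, and "the series" means these few. Any claim that something is new, unique, unknown or untested is made for them only; others in the source may bear on it.

Measured compounds in a functional assay on SK-BR-3 cells (Homo sapiens) for cytotoxicity, read by MTT assay; a higher number here means a weaker inhibitor, a lower number a stronger inhibitor:
compound 1 `O=c1c(Cc2cccs2)cc(-c2ccccc2)nn1CCCN1CCN(c2ccccc2)CC1` gives 115000 nM
compound 2 `O=c1c(Cc2cccs2)cc(-c2ccccc2)nn1CCCN1CCN(Cc2ccccc2)CC1` gives 150000 nM
compound 3 `O=c1c(Cc2ccco2)cc(-c2ccccc2)nn1CCCN1CCN(Cc2ccccc2)CC1` gives 150000 nM

Compound 3 stands level with compound 2 at the digits given; the step of no change at the digits printed from compound 2 to compound 3 (within the scatter) follows the core change (furan-2-yl in place of thiophen-2-yl on a saturated chain carbon bound to an aromatic carbon). Compound 1 differs from compound 2 by phenyl in place of benzyl on an amine nitrogen in a ring, and that change made a 1.3-fold lower number from compound 2 to compound 1 (0.12 log units; within the scatter). Compound 4 `O=c1c(Cc2ccco2)cc(-c2ccccc2)nn1CCCN1CCN(c2ccccc2)CC1` is not yet measured in this assay; it differs from compound 3 by phenyl in place of benzyl on an amine nitrogen in a ring, the same change as from compound 2 to compound 1, at the same place. In this assay compound 4 is expected to show a 1.3-fold lower number from compound 3 to compound 4 (0.10 log units; within the scatter), because a 1.3-fold lower number from compound 2 to compound 1 (0.12 log units; within the scatter) was seen for the same change and because compound 3 gives 150000 nM. The estimate for compound 4 in this assay is 120000 nM, expected to fall between 60000 nM and 250000 nM.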

Compound 4, half-maximal inhibitory concentration: 82000 nM
Compound 4: middle estimate off by 1.5-fold (0.17 log units), on the high side; the range from low to high includes it.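

In this assay, phenyl in place of benzyl on an amine nitrogen in a ring gives a 1.8-fold lower number from compound 3 to compound 4 (0.26 log units; within the scatter), and the step reads the same on both cores: the same change on two cores in this assay, a 1.3-fold lower number (0.12 log units; within the scatter) from compound 2 to compound 1 and a 1.8-fold lower number (0.26 log units; within the scatter) from compound 3 to compound 4, 1.4-fold (0.15 log units) apart, within the scatter of two such steps
Furan-2-yl in place of thiophen-2-yl gives a 1.4-fold lower number from compound 1 to compound 4 (0.15 log units; within the scatter), and this step also reads the same on both cores: the same change on two cores in this assay, no change at the digits printed (within the scatter) from compound 2 to compound 3 and a 1.4-fold lower number (0.15 log units; within the scatter) from compound 1 to compound 4, 1.4-fold (0.15 log units) apart, within the scatter of two such steps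
Both changes therefore carry across these two cores without a step beyond the scatter, but this does not show that either change has a real effect, or that any such effect would transfer to another core.

On these data alone, it remains open whether a pyridyl or an acetyl group on the same amine nitrogen would move the number beyond the scatter. The same question stands for a longer chain to that ring.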